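Methyl in Place of Phenyl: Expected Permeability of Compound 3

A few compounds are considered here, and "the series" means these few. Any claim that something is new, unique, unknown or untested is made for them only; others in the source may bear on it.

In an ADME assay for permeability, using PAMPA, with a stated time of 4 h (on this read-out lower numbers stand for lower permeability and higher numbers for higher permeability), compound 2 `Cc1c(F)c([N+](=O)[O-])cc(C(=O)Nc2cc(C(=O)Oc3ccccc3)ccc2N2CCN(C)CC2)c1Cl` gives 56.3 10^-6 cm/s, a number that sits with the only other one in hand, that of compound 1 `COC(=O)c1ccc(N2CCN(C)CC2)c(NC(=O)c2cc(N)c(F)c(C)c2Cl)c1`, which gives 52.9 10^-6 cm/s in this assay, inside the usual scatter. Compound 3 `COC(=O)c1ccc(N2CCN(C)CC2)c(NC(=O)c2cc([N+](=O)[O-])c(F)c(C)c2Cl)c1` has not yet been measured in this assay. It differs from compound 2 by methyl in place of phenyl on an oxygen next to a carbonyl group. No step beyond the scatter is expected, because compound 1 carries the methoxycarbonyl group and gives 52.9 10^-6 cm/s in this assay. The expected step of a 1.1-fold lower number from compound 2 to compound 3 (0.05 log units; within the scatter) is essentially none. Compound 3 is therefore estimated at 50 10^-6 cm/s, with a range from 30 10^-6 cm/s to 80 10^-6 cm/s.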

Compound 3, apparent permeability: 74.8 10^-6 cm/s
Compound 3: the middle estimate sits 1.5-fold (0.17 log units) below what was measured; the range from low to high includes it.
By their numbers in this assay, from the lowest: compounds 1, 2 and 3 (each within the scatter of the next).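

In this assay the exchange of phenyl for methyl on an oxygen next to a carbonyl group gives a 1.3-fold higher number from compound 2 to compound 3 (0.12 log units; within the scatter) and so shows that this position takes either group without a step beyond the scatter. Nitro in place of amino on an aromatic carbon gives a 1.4-fold higher number from compound 1 to compound 3 (0.15 log units; within the scatter) and adds a second single change that stays inside the scatter. No other measurement is at hand that bears on these results.

Still open, going by these compounds, is whether a carboxylic acid or a longer chain such as butyl on that oxygen would also stay within the scatter. On these data alone, an amine in place of the methoxy group remains equally open.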